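A few compounds are considered here, and "the series" means these few. Any claim that something is new, unique, unknown or untested is made for them only; others in the source may bear on it.

Compound 1 `CC(C)N(Cc1cccc(OCCCCCC(=O)O)c1)C(=O)c1ccc(-c2ccncc2)cc1` gives > 26000 nM in an ADME assay on BJ cells (Homo sapiens) for cytotoxicity, read by CellTiter-Glo and resazurin assay, with a stated time of 72 h (a lower number here means that less compound is needed, a higher number that more compound is needed for the effect), which is a limit of the assay rather than a number.
Compound 2 `CCOC(=O)CCCCCOc1cccc(CN(C(=O)c2ccccc2)C(C)C)c1` gives > 26000 nM in this assay, again a limit.
Compound 3 `CCOC(=O)CCCCCOc1cccc(CN(C(=O)c2ccc(-c3ccncc3)cc2)C(C)C)c1` gives > 26000 nM in this assay, also a limit.

Compound 3 therefore stands where every measured compound stands: at the limit, with no number of its own. The two changes leading to it cannot be read for size. The step that the two limits leave unreadable from compound 1 to compound 3, an ethyl in place of hydrogen on an oxygen next to a carbonyl group, and the step that the two limits leave unreadable from compound 2 to compound 3, a pyridin-4-yl in place of hydrogen on an aromatic carbon, both run from one limit to another, and this is all that the limit of > 26000 nM in this assay, at which 3 of the 3 values shown sit, shows.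

Compound 4 `CCOC(=O)CCCCCOc1cccc(CN(C(=O)c2ccc(-c3ccoc3)cc2)C(C)C)c1` differs from compound 3 in one place: furan-3-yl in place of pyridin-4-yl on an aromatic carbon. Going by the values given here, no measured step touches this change, and the measured steps give no size either way. Among the compounds with values here, the only guide is that every compound so far sits at the limit, so compound 4 is expected to do the same, with a step that the limit leaves unreadable from compound 3 to compound 4 that is expected to mean no readable change.

Compound 4 is therefore estimated at 35000 nM in this assay, within a range of 15000 nM to 120000 nM, and most likely reported only as a limit.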

Compound 4, half-maximal effective concentration: > 26000 nM
Compound 4 gave a limit, no number; the forecaster's own chance of this, stated with the estimate: 80%; the middle value does not contradict the limit.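

Neither the step from compound 3 to compound 4 nor the step from compound 2 to compound 4 can be read for size, and compound 4 adds only one more limit to the record: the limit of > 26000 nM in this assay, at which 4 of the 4 values shown sit.

The compounds shown leave open whether any of them has a measurable effect in this assay at all, and at what concentration that effect would appear.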